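This account rests on a few compounds, and the source may have more. Where it says the series, first, only, none or still open, it means among the compounds named here.

In a functional assay on the whole organism (strain Kunming) with Mus musculus as the target, with a stated time of 0.5 h (a lower number here means that less compound is needed, a higher number that more compound is needed for the effect), compound 1 (`COc1cc(OC)c(OC)cc1/C=C/COC(=O)/C=C/c1ccccc1Cl`) gives 248 mg/kg and compound 2 (`COc1cccc(/C=C/C(=O)OC/C=C/c2cc(OC)c(OC)cc2OC)c1`) gives 249 mg/kg so the two stand level. Compound 2 thus has no measured neighbour that separates from it, and a 1.0-fold higher number from compound 1 to compound 2 (0.00 log units; within the scatter) is a step within the scatter. The next compound to be measured is compound 3 (`COc1cc(OC)c(OC)cc1/C=C/COC(=O)/C=C/c1ccc(Cl)cc1`), which keeps the shared core of compound 2 and differs at a single place: 4-chlorophenyl in place of 3-methoxyphenyl on a double-bonded chain carbon bound to a double-bonded chain carbon. Within the data shown here, only one measured step bears on this change. At the same place, going from 2-chlorophenyl to 3-methoxyphenyl gave a 1.0-fold higher number from compound 1 to compound 2 (0.00 log units; within the scatter) and left the number within the scatter. Among the measured compounds shown here, no measured compound carries 4-chlorophenyl, so this single step is thin support, and the range has to stay wide. In this assay the expected outcome is a 1.0-fold lower number from compound 2 to compound 3 (0.02 log units; within the scatter) and so no change beyond the scatter. For compound 3 the estimated value is 240 mg/kg with 125 mg/kg to 460 mg/kg as the expected range.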

Compound 3, dose for half-maximal effect: > 200 mg/kg
Compound 3: a limit, no number; the forecaster's own chance of this, stated with the estimate: 5%; the middle value is on the limit's open side.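

In this assay compound 3 gives > 200 mg/kg as a limit and not as a number. The steps from compound 1 and from compound 2 to compound 3 therefore cannot be read. The compounds shown leave open whether 4-chlorophenyl stands level with 2-chlorophenyl and 3-methoxyphenyl or apart from them.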